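A few compounds are considered here, and "the series" means these few. Any claim that something is new, unique, unknown or untested is made for them only; others in the source may bear on it.

Working notes on the series. The shared core carries a piperazine amide linked through a methylene to a second piperazine bearing an aryl group, and the three measured compounds differ only in that aryl group. Compound 1 `O=C(CN1CCN(c2ccccc2)CC1)N1CCN(c2nnc(-c3ccc(Cl)cc3)c(-c3ccc(Cl)cc3)n2)CC1` carries a plain phenyl ring. In a functional assay on MCF7 cells (Homo sapiens) for cytotoxicity, read by MTT assay, with a stated time of 24 h (a lower number here means a stronger inhibitor, a higher number a weaker inhibitor), compound 1 gives a limit of the assay, > 850000 nM. Compound 2 `O=C(CN1CCN(c2ccccc2Cl)CC1)N1CCN(c2nnc(-c3ccc(Cl)cc3)c(-c3ccc(Cl)cc3)n2)CC1` carries a 2-chlorophenyl ring, and in this assay compound 2 gives 396000 nM. Compound 3 `COc1ccc(N2CCN(CC(=O)N3CCN(c4nnc(-c5ccc(Cl)cc5)c(-c5ccc(Cl)cc5)n4)CC3)CC2)cc1` carries a 4-methoxyphenyl ring. In this assay compound 3 gives a limit of the assay, > 809000 nM. So compound 3 stands at a limit, and one further value in the set, that of compound 1, is a limit as well the limit of > 809000 nM in this assay, at which 1 of the 3 values shown sits (the limit of > 850000 nM in this assay, at which 1 of the 3 values shown sits).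

Among the measured steps, an at least 2.1-fold lower number from compound 1 to compound 2 (0.33 log units; beyond the scatter), and an at least 2.0-fold higher number from compound 2 to compound 3 (0.31 log units; beyond the scatter), while a step that the two limits leave unreadable from compound 1 to compound 3.

Compound 4 `O=C(CN1CCN(c2ccc(Cl)cc2)CC1)N1CCN(c2nnc(-c3ccc(Cl)cc3)c(-c3ccc(Cl)cc3)n2)CC1` is not yet measured. The change from compound 3 is chloro in place of methoxy on an aromatic carbon, on an aromatic carbon of a six-membered aromatic ring of carbon only, para to a large group; one bond further out it reads 4-methoxyphenyl to 4-chlorophenyl. Among the measured compounds shown here, no measured step exchanges chloro for methoxy directly. For the measured compounds named here, the only step that introduces chloro is an at least 2.1-fold lower number from compound 1 to compound 2 (0.33 log units; beyond the scatter), and the only step that introduces methoxy runs into a limit. From this, compound 4 is expected to give a number near or somewhat under the limit of compound 3, with an at least 1.6-fold lower number from compound 3 to compound 4 (0.20 log units; that floor lies within the scatter) the estimated step. The estimate for compound 4 in this assay is 500000 nM, between 150000 nM and 900000 nM.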

Compound 4, half-maximal inhibitory concentration: > 803000 nM
Compound 4: a limit, no number; the forecaster's own chance of this, stated with the estimate: 40%; at least 1.6-fold (0.20 log units) between middle value and limit.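

In this assay compound 4 stands at a limit of the assay, > 803000 nM. The 4-chlorophenyl ring in place of the 2-chlorophenyl ring gives an at least 2.0-fold higher number from compound 2 to compound 4 (0.30 log units; that floor lies within the scatter), so a chloro group on the aryl ring does not by itself bring a compound to a measured number, and among the rings shown only the 2-chlorophenyl ring reaches one, although the floor of this step does not separate the two chloro rings beyond the scatter. The steps to compound 4 from compound 1 and from compound 3 join two limits and cannot be read, so neither chloro against hydrogen nor chloro against methoxy at this ring carbon, para to a large group, has a size.

Left open is whether a 2-methoxyphenyl ring would reach a measured number as the 2-chlorophenyl ring does, which would show whether that ring place or the chloro group goes with the lower number. Also open, on these data alone, is what a carboxylic acid or an amine on the same aromatic carbon, para to a large group, would give in this assay.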